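Methyl on the pendant phenyl of compound 3

The source may report more compounds than this note shows. Statements on the series, on what has been measured and on what is new or still open speak of the compounds shown alone.

Measured in a functional assay on NCI-H460 cells (Homo sapiens) for cytotoxicity, read by MTT assay, with a stated time of 72 h; on this read-out lower numbers stand for stronger inhibition and higher numbers for weaker inhibition:
compound 1 `COc1cc2c(Oc3ccc(NC(=O)c4nccc(-c5ccc(C)cc5)n4)cc3F)ccnc2cc1OCCCN1CCCCC1`: 230 nM
compound 2 `COc1cc2c(Oc3ccc(NC(=O)c4nccc(-c5ccc(C)cc5)n4)cc3F)ccnc2cc1OCCCN1CCN(C)CC1`: 160 nM
compound 3 `COc1cc2c(Oc3ccc(NC(=O)c4nccc(-c5ccccc5)n4)cc3F)ccnc2cc1OCCCN1CCCC1`: 1120 nM

Compound 3 stands highest of the three in this assay, beyond the scatter from both others; compound 1 gives 230 nM and compound 2 gives 160 nM. Compound 4 `COc1cc2c(Oc3ccc(NC(=O)c4nccc(-c5ccc(C)cc5)n4)cc3F)ccnc2cc1OCCCN1CCCC1` differs from compound 3 by methyl in place of hydrogen on an aromatic carbon. Among the measured compounds shown here, the only single-point step measured, a 1.4-fold lower number from compound 1 to compound 2 (0.16 log units; within the scatter), concerns the amine on the chain and says nothing about the methyl. Compound 1 and compound 3 differ in two places at once, the aryl methyl and the amine ring, so their gap cannot be split between them. Compound 4 is therefore expected to move toward lower numbers, a 2.5-fold lower number from compound 3 to compound 4 (0.40 log units; beyond the scatter), with a wide range. Compound 4 is estimated at 450 nM (180 nM to 1100 nM).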

Compound 4, half-maximal inhibitory concentration: 440 nM
Compound 4: middle estimate off by 1.0-fold (0.01 log units), on the high side, and the stated range covers the measured number.
By their numbers in this assay, from the lowest: compounds 2, 1 and 4 (each within the scatter of the next, the first and the last beyond it); then compound 3.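

In this assay, among the compounds shown here, with pyrrolidin-1-yl held constant, phenyl to 4-methylphenyl gives a 2.5-fold lower number from compound 3 to compound 4 (0.41 log units; beyond the scatter) and so isolates the methyl, para to a large group, for the first time. With 4-methylphenyl held constant, the amine step from 4-methylpiperazin-1-yl gives a 2.8-fold higher number from compound 2 to compound 4 (0.44 log units; beyond the scatter) and lies beyond the scatter, whereas the step from piperidin-1-yl gives a 1.9-fold higher number from compound 1 to compound 4 (0.28 log units; within the scatter) and lies within it. Nothing available explains either the methyl step or the amine step.

Going by these compounds, whether the methyl step carries over to the piperidin-1-yl and 4-methylpiperazin-1-yl compounds stays open. Also open, on these data alone, is how chlorine or a methoxy group on the same aromatic carbon would compare with methyl.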